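Trifluoromethyl for Carbamoyl on Two Cores

The source may report more compounds than this note shows. Statements on the series, on what has been measured and on what is new or still open speak of the compounds shown alone.

Measured compounds:
compound 1, `Cc1n[nH]c(C(=O)O)c1Cc1cccc(-c2ccc(C(N)=O)cc2)c1`, 200 nM
compound 2, `Cc1n[nH]c(C(=O)O)c1Cc1cccc(C(N)=O)c1`, 900 nM
compound 3, `Cc1n[nH]c(C(=O)O)c1Cc1cccc(C(F)(F)F)c1`, 300 nM

The three measured compounds were tested in an assay on isolated protein for inhibition of 2-Hydroxyacid oxidase 2 (Rattus norvegicus); on this read-out lower numbers stand for stronger inhibition and higher numbers for weaker inhibition. Compound 1 gives 200 nM, and compound 2, which carries a smaller core, gives 900 nM. The difference between the two cores is not broken down here. Compound 3 gives 300 nM. Compound 1 has the lowest of the three numbers; its gap to compound 3 lies within the scatter, while its gap to compound 2 lies beyond it.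

One change has already been measured once. From compound 2 to compound 3 the change is trifluoromethyl in place of carbamoyl on an aromatic carbon, and it produced a 3.0-fold lower number from compound 2 to compound 3 (0.48 log units; beyond the scatter). The unmeasured compound 4, `Cc1n[nH]c(C(=O)O)c1Cc1cccc(-c2ccc(C(F)(F)F)cc2)c1`, is obtained from compound 1 by trifluoromethyl in place of carbamoyl on an aromatic carbon. The two changes are the same kind of change, not the same: in the first, the group sits meta to a large group, in the second, para to a large group.

Resting on the step seen from compound 2 to compound 3, compound 4 is expected to give a number lower than that of compound 1, by about a 2.2-fold lower number from compound 1 to compound 4 (0.35 log units; beyond the scatter). The place of the change differs in the two cases, and the expected step is set somewhat smaller than a 3.0-fold lower number from compound 2 to compound 3 (0.48 log units; beyond the scatter). Compound 4 is therefore estimated at 90 nM, within a range from 35 nM to 250 nM.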

Compound 4, half-maximal inhibitory concentration: 400 nM
For compound 4 the middle estimate is 4.4-fold (0.65 log units) below the measured one, and the stated range ends below it.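

In this assay placing trifluoromethyl where carbamoyl stood on the core of compound 1 gives a 2.0-fold higher number from compound 1 to compound 4 (0.30 log units; within the scatter), so compound 1 and compound 4 cannot be told apart on this read-out. Set beside the earlier step, the same change did not keep its size or direction from one core to the other, and the two results differ by more than repeated measurement would explain: the same change on two cores in this assay, a 3.0-fold lower number (0.48 log units; beyond the scatter) from compound 2 to compound 3 and a 2.0-fold higher number (0.30 log units; within the scatter) from compound 1 to compound 4, 6.0-fold (0.78 log units) apart, beyond the scatter of two such steps. Going by these compounds alone, this shows that the lower number seen on the smaller core is no safe guide to the outcome on the core of compound 1, but with only two pairs it does not show which difference between the cores sets the two steps apart, what part the place of the group, para to a large group in compound 4, plays, or how the change would behave on any other core.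

The compounds shown leave open how an amine or a nitrile would compare with carbamoyl and trifluoromethyl at the same place on either core. They also leave open whether a longer chain in place of the direct link between the two rings of compound 1 would bring the step back towards the one seen on the smaller core.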